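Nitro on the shared core: compound 3 to compound 4

The compounds below may be only part of what the source reports. "The series", "measured", "known", "first", "only" and "open" are said of these compounds alone.

In an ADME assay on HepG2 cells (Homo sapiens) for inhibition, read by fluorescence and resazurin assay, with a stated time of 72 h (on this read-out higher numbers stand for weaker inhibition and lower numbers for stronger inhibition), compound 3 `Cc1cccc(Nc2nccc(Nc3ccc4nc[nH]c4c3)n2)c1` gives 20000 nM and compound 2 `Cc1cc(Nc2nccc(Nc3ccc4nc[nH]c4c3)n2)ccc1N1CCN(C)CC1` gives 15000 nM, two values within the scatter of each other. Compound 1 `CS(=O)(=O)Nc1cccc(Nc2nccc(Nc3ccc4nc[nH]c4c3)n2)c1` returns only a limit, > 25000 nM.

Compound 4 `Cc1cccc(Nc2ncc([N+](=O)[O-])c(Nc3ccc4nc[nH]c4c3)n2)c1` is compound 3 with nitro in place of hydrogen on an aromatic carbon of the six-membered aromatic ring with 2 nitrogen (nitro in place of hydrogen on an aromatic carbon). Two measured steps are available: an at least 1.2-fold lower number from compound 1 to compound 3 (0.09 log units; that floor lies within the scatter) and a 1.3-fold higher number from compound 2 to compound 3 (0.12 log units; within the scatter). Both are small, but neither changes the carbon where the nitro enters, so they show only how flat this assay has been across this short series. Within the data shown here, no measured step tests this change directly, which calls for a wide range. The central expectation is a modest move to a lower number, not beyond the scatter. The estimate corresponds to a 1.7-fold lower number from compound 3 to compound 4 (0.22 log units; within the scatter). For compound 4 the expected value is 12000 nM, with an estimated range of 3500 nM to 25000 nM.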

Compound 4, half-maximal inhibitory concentration: 22000 nM
The estimate for compound 4 lay 1.8-fold (0.26 log units) below the measured number; measured number inside the range.
By their numbers in this assay, from the lowest: compounds 2, 3 and 4 (each within the scatter of the next). At a limit, above all of these: compound 1.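

In this assay, nitro in place of hydrogen on the aromatic carbon para to the (3-methylphenyl)amino group gives a 1.1-fold higher number from compound 3 to compound 4 (0.04 log units; within the scatter). The earlier steps shown here changed groups on a different ring, whereas this step shows that the shared core also carries nitro at this carbon, ortho to a large group and two atoms from the ring nitrogen, with no move beyond the scatter. Compound 1 remains the only entry given as a limit: the limit of > 25000 nM in this assay, at which 1 of the 4 values shown sits.

Going by these compounds, it remains open whether an amine, a carboxylic acid or a longer chain on this carbon would also stay within the scatter. On these data alone, it is equally open whether nitro would give so small a step on the core of compound 2, which carries 4-methylpiperazin-1-yl.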